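Trimming a tert-Butyl Group on a Kinase Inhibitor

The source may hold more compounds than are shown below. What is called first, only, known or untested is meant among the compounds shown, and "the series" means these compounds.

Measured so far in an assay on isolated protein for inhibition of Rho-associated protein kinase 2 (Homo sapiens), read by a luciferase reporter; a lower number here means a stronger inhibitor, a higher number a weaker inhibitor:
compound 1, `CC(C)(C)c1cccc(C2CNCC2C(=O)Nc2cc3cc[nH]c(=O)c3cc2Cl)c1`: 11 nM
compound 2, `O=C(Nc1cc2cc[nH]c(=O)c2cc1Cl)[C@@H]1CCCNC1`: 47 nM

Compound 1 gives the lower of the two numbers; compound 2 sits clearly above it, beyond the usual scatter. Compound 3, `CCc1cccc(C2CNCC2C(=O)Nc2cc3cc[nH]c(=O)c3cc2Cl)c1`, differs from compound 1 in one place: ethyl in place of tert-butyl on an aromatic carbon. Among the compounds with values here, no measured pair shows this exact change, so its effect cannot be read from the numbers at hand. The expectation is a small loss of potency or none beyond the scatter, a modest upward step a 1.8-fold higher number from compound 1 to compound 3 (0.26 log units; within the scatter). Compound 3 is therefore estimated at 20 nM, between 7 nM and 60 nM.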

Compound 3, half-maximal inhibitory concentration: 4 nM
Beside the measured number, compound 3's estimate is 5.0-fold (0.70 log units) above it; measured number outside the range, below it.
By their numbers in this assay, from the lowest: compound 3; then compound 1; then compound 2.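

Swapping tert-butyl for ethyl gives a 2.8-fold lower number from compound 1 to compound 3 (0.44 log units; beyond the scatter) in this assay on this isolated kinase. This position on the aromatic ring therefore does not need the full tert-butyl group: ethyl, with 2 heavy carbons in place of 4, does better here. Nothing available here accounts for the gain. Still open, going by these compounds, is whether an even smaller methyl group would continue this gain or lose it. The compounds shown also leave open how an amine or a longer propyl chain would fare at this carbon.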